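From Chloro to Ethynyl on an Antiproliferative Amide

The source may hold more compounds than are shown below. What is called first, only, known or untested is meant among the compounds shown, and "the series" means these compounds.

Three amides sharing one core have been measured in a functional assay on SK-OV-3 cells (Homo sapiens) for antiproliferative activity, read by MTT assay, with a stated time of 72 h; a lower number here means a stronger inhibitor, a higher number a weaker inhibitor. Compound 1 (`O=C(CCc1cccc2c1B(O)OC2)NC1CCCCC1`), with cyclohexyl on the amide nitrogen, gives > 100000 nM, which is a limit of the assay and not a number. Compound 2 (`O=C(CCc1cccc2c1B(O)OC2)NCc1ccccc1`), with benzyl there, gives > 100000 nM, again a limit. Within the data shown here, compound 3 (`O=C(CCc1cccc2c1B(O)OC2)Nc1ccc(Cl)cc1`), with 4-chlorophenyl there, gives 5000 nM, the only actual number so far. Benzyl in place of cyclohexyl is a step that the two limits leave unreadable from compound 1 to compound 2. The 4-chlorophenyl group in place of cyclohexyl gives an at least 20-fold lower number from compound 1 to compound 3 (1.30 log units; beyond the scatter), and in place of benzyl it gives an at least 20-fold lower number from compound 2 to compound 3 (1.30 log units; beyond the scatter).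

Compound 4 (`C#Cc1ccc(NC(=O)CCc2cccc3c2B(O)OC3)cc1`) differs from compound 3 by one change, ethynyl in place of chloro on an aromatic carbon. Both large steps exchange the whole group on the amide nitrogen, whereas this change leaves the phenyl group in place, so they bear on it only loosely. Among the measured compounds shown here, no measured step alters the chloro itself. Starting from compound 3 at 5000 nM, no step beyond the scatter is therefore expected in this assay, and neither direction is favoured. The expected result is no change at the digits printed from compound 3 to compound 4 (within the scatter). Compound 4 is estimated at 5000 nM, with an expected range of 1500 nM to 20000 nM.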

Compound 4, half-maximal inhibitory concentration: 6300 nM
Compound 4: the middle estimate sits 1.3-fold (0.10 log units) below what was measured, within the range that was stated.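

In this assay, among these compounds, ethynyl in place of chloro gives a 1.3-fold higher number from compound 3 to compound 4 (0.10 log units; within the scatter), the first step read between two actual numbers and not against a limit. The earlier steps shown here exchanged the whole group on the amide nitrogen, whereas this one keeps the phenyl ring and the amide and alters only the group on an aromatic carbon, para to a large group. It shows that this place accepts ethynyl, with its triple bond, in place of chlorine without a change beyond the scatter, so in these two compounds the value does not depend on the chlorine itself.

Two compounds cannot show whether this tolerance extends to other groups at the same place, such as an amine, a carboxylic acid, a methoxy group or a longer chain, or whether a plain phenyl ring with only hydrogen there would hold the value. The weak end of the series also remains unresolved, and how far cyclohexyl and benzyl actually lie from the 4-chlorophenyl amide cannot be read: the limit of > 100000 nM in this assay, at which 2 of the 4 values shown sit.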